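Aryl swap on an anilino-quinone core: compound 4 expected

A few compounds are considered here, and "the series" means these few. Any claim that something is new, unique, unknown or untested is made for them only; others in the source may bear on it.

Measured compounds in a functional assay on HeLa cells (Homo sapiens) for inhibition, read by sulforhodamine B assay; on this read-out lower numbers stand for stronger inhibition and higher numbers for weaker inhibition:
compound 1 `O=C1C=C(Nc2ccc(I)cc2)C(=O)c2c1nc1n2[C@H]2OC[C@@H](O)[C@H]2OC1` gives 4070 nM
compound 2 `Cc1ccc(NC2=CC(=O)c3c(nc4n3[C@H]3OC[C@@H](O)[C@H]3OC4)C2=O)cc1C` gives 4320 nM
compound 3 `O=C1C=C(Nc2ccc(Br)cc2)C(=O)c2c1nc1n2[C@H]2OC[C@@H](O)[C@H]2OC1` gives 3830 nM

All three values lie within the scatter of one another; compound 2 sits at the highest of the three numbers, yet its nearest neighbour compound 1 and its furthest neighbour compound 3 both fall within the scatter of it. For the measured compounds named here, the only step between compounds that differ in one place, a 1.1-fold lower number from compound 1 to compound 3 (0.03 log units; within the scatter), is also within the scatter.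

Compound 4 `O=C1C(Nc2cccc(F)c2)=CC(=O)c2c1nc1n2[C@H]2OC[C@@H](O)[C@H]2OC1` is not yet measured. It differs from compound 2 by 3-fluorophenyl in place of 3,4-dimethylphenyl on an amine nitrogen. Going by the values given here, no measured step changes the group on the amine nitrogen in this way, and the one step that does change the aryl ring, a 1.1-fold lower number from compound 1 to compound 3 (0.03 log units; within the scatter), was within the scatter. Compound 4 is therefore expected to show no step beyond the scatter, a 1.0-fold higher number from compound 2 to compound 4 (0.02 log units; within the scatter). The estimated value of compound 4 in this assay is 4500 nM, with a range from 1800 nM to 11000 nM.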

Compound 4, half-maximal inhibitory concentration: > 8000 nM
Compound 4 gave a limit, no number; the forecaster's own chance of this, stated with the estimate: 5%; at least 1.7-fold (0.24 log units) between middle value and limit.
By their numbers in this assay, from the lowest: compounds 3, 1 and 2 (each within the scatter of the next). At a limit, above all of these: compound 4.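

In this assay compound 4 gives > 8000 nM, which is a limit of the assay and not a number. Placing 3-fluorophenyl instead of 3,4-dimethylphenyl on the amine nitrogen is the only change shown that ends at such a limit, and the step reads an at least 1.8-fold higher number from compound 2 to compound 4 (0.26 log units; that floor lies within the scatter). The aryl group here may therefore matter more than the bromo and iodo pair, compound 1 and compound 3, suggested, but the floor of this step does not establish a difference beyond the scatter.

On these data alone, the true value of compound 4 stays open, as does whether the fluorine or the missing methyl groups account for the limit. Also open, as far as these compounds go, is how an aryl ring carrying an amine or a carboxylic acid would read out.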